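Adding a methylpiperazine to the sulfonyl aryl ring

The source may report more compounds than this note shows. Statements on the series, on what has been measured and on what is new or still open speak of the compounds shown alone.

Measured so far:
compound 1 `COc1cc(N)c(Cl)cc1C(=O)CCC1CCN(CCNS(=O)(=O)c2ccc3c(c2)NC(=O)CO3)CC1`: 40%
compound 2 `COc1ccc(S(=O)(=O)NCCN2CCC(CCC(=O)c3cc(Cl)c(N)cc3OC)CC2)cc1Br`: 72%
compound 3 `COc1ccc(S(=O)(=O)NCCN2CCC(CCC(=O)c3cc(Cl)c(N)cc3OC)CC2)cc1`: 52%

In an assay on HEK293 cells for displacement of a labelled ligand from 5-hydroxytryptamine receptor 6 (Homo sapiens), with a stated time of 60 min, tested at 1 uM, in the presence of a further agent that is not named here (a higher number here means a stronger effect of the compound at the concentration tested, a lower number a weaker effect), compound 3 stands second highest of the three numbers. The step of a number 12 percentage points higher from compound 1 to compound 3 (beyond the scatter) is modest, and the step of a number 20 percentage points lower from compound 2 to compound 3 (beyond the scatter) is also modest, so compound 3 sits between the other two.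

Compound 4 `COc1cc(N)c(Cl)cc1C(=O)CCC1CCN(CCNS(=O)(=O)c2ccc(OC)c(N3CCN(C)CC3)c2)CC1` differs from compound 3 in one place: 4-methylpiperazin-1-yl in place of hydrogen on an aromatic carbon. The entering group sits ortho to a methoxy group, the same position that carried bromo in compound 2. The step of a number 20 percentage points lower from compound 2 to compound 3 (beyond the scatter) shows that a substituent at this position went along with a higher number; compound 1, which also carries a ring with two hetero atoms, gave the lowest number. The change from compound 3 to compound 4 is therefore expected to give a modest rise, a number 8 percentage points higher from compound 3 to compound 4 (within the scatter), though a step within the scatter would not be surprising. For compound 4 the estimate is 60%, with a range from 38% to 82%.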

Compound 4, a percentage reported as inhibition, at one concentration (the size of the read-out at that concentration, not a potency): 43%
The estimate for compound 4 lay 17 percentage points above the measured number, within the range that was stated.
By their numbers in this assay, from the lowest: compounds 1, 4 and 3 (each within the scatter of the next, the first and the last beyond it); then compound 2.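

In this assay, 4-methylpiperazin-1-yl at this position gives a number 9 percentage points lower from compound 3 to compound 4 (within the scatter), so it cannot be told apart from hydrogen here. Against bromo, the same change gives a number 29 percentage points lower from compound 2 to compound 4 (beyond the scatter), so the higher number seen with bromo does not extend to every substituent at this position. Nothing measured here explains why the two groups differ.

On these data alone, whether chloro or a simple amine at this position would read like bromo or like hydrogen stays open. So does whether a piperazine without its methyl would differ from compound 4.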